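This account rests on a few compounds, and the source may have more. Where it says the series, first, only, none or still open, it means among the compounds named here.

In a functional assay on Jurkat cells (Homo sapiens) for cytotoxicity, read by luminescence and CellTiter-Glo, with a stated time of 3 days (a higher number here means a weaker inhibitor, a lower number a stronger inhibitor), compound 1 `O=C(Nc1cc(C(F)(F)F)cc(C(F)(F)F)c1)c1cc(Br)c(-c2ccccc2)cc1O` gives 680 nM. Compound 2 `O=C(Nc1ccc(Cl)cc1Cl)c1cc(F)ccc1O` gives 880 nM, a number within the usual scatter of compound 1, so these two cannot be told apart. Compound 3 `N#Cc1cc(Cl)ccc1NC(=O)c1ccc2cccnc2c1O` gives 170 nM, a lower number than compound 1 by more than the scatter, and so it is the stronger inhibitor of that pair. Compound 1 thus sits level with compound 2 at the weaker end of this small set.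

Compound 4 `O=C(Nc1cc(C(F)(F)F)cc(C(F)(F)F)c1)c1ccc(-c2ccccc2)cc1O` has not yet been measured. It is compound 1 with a single change: hydrogen in place of bromo on an aromatic carbon, ortho to a phenyl group and para to a hydroxy group. The rest of the structure stays the same.

For the measured compounds named here, no two measured compounds differ in one place only, so the data give no direct size for this change. Going by the values given here, the only anchor is compound 1 at 680 nM. In this assay a small step is expected, quite possibly none beyond the scatter, with a slight lean towards a higher number, which would mean a weaker inhibitor. The estimated step is a 1.3-fold higher number from compound 1 to compound 4 (0.12 log units; within the scatter). The expected value for compound 4 is 900 nM, with an estimated range from 300 nM to 2700 nM.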

Compound 4, half-maximal inhibitory concentration: 1240 nM
Compound 4: the middle estimate sits 1.4-fold (0.14 log units) below what was measured; measured number inside the range.
By their numbers in this assay, from the lowest: compound 3; then compounds 1, 2 and 4 (each within the scatter of the next).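

For the compounds shown here, compounds 1 and 4 are the first pair here that differ in one place only, so a bromo group on this aromatic carbon, ortho to a phenyl group and para to a hydroxy group, can be compared directly with hydrogen. In this assay the pair shows a 1.8-fold higher number from compound 1 to compound 4 (0.26 log units; within the scatter) and so cannot be told apart, which means that this single comparison gives no sign that the activity of compound 1 depends on the bromo group. Nothing measured here explains this result or shows what the bromo group does at this position.

One replacement cannot show whether other groups on the same carbon would also match hydrogen or would stand clearly apart from it, for example a methoxy group, an amine or a carboxylic acid. On these data alone, it also remains open whether swapping bromo for hydrogen would give a similarly small step if the two trifluoromethyl groups shared by compounds 1 and 4 were replaced, or if the phenyl group were removed.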